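Working notes: chloro in place of methoxy, compound 4

The compounds below may be only part of what the source reports. "The series", "measured", "known", "first", "only" and "open" are said of these compounds alone.

Measured in an in vitro assay on cells for inhibition of Amine oxidase [flavin-containing] B (Homo sapiens), read by Amplex Red, with a stated time of 15 min; a lower number here means a stronger inhibitor, a higher number a weaker inhibitor:
compound 1 `CNC(=S)N1CCC(c2cccc(OC)c2)=N1` gives 71300 nM
compound 2 `CNC(=S)N1CC(C)C(c2ccc(OC)cc2)=N1` gives 49400 nM
compound 3 `COc1ccc(C2=NN(C(N)=S)CC2C)cc1` gives 84600 nM

Compound 2 carries the lowest number of the three, with compound 1 nearest and compound 3 furthest, both within the scatter of it, so the three are not distinguished in this assay. Within the data shown here, the only single-point step measured, a 1.7-fold higher number from compound 2 to compound 3 (0.23 log units; within the scatter), concerns hydrogen in place of methyl on an amide-type nitrogen and leaves the aromatic ring untouched. Compound 4 `CNC(=S)N1CC(C)C(c2ccc(Cl)cc2)=N1` is compound 2 with chloro in place of methoxy on an aromatic carbon. Among the measured compounds shown here, no measured step alters this position, so nothing argues for a move beyond the scatter. Compound 4 is expected near 35000 nM, between 10000 nM and 120000 nM. The expected step is a 1.4-fold lower number from compound 2 to compound 4 (0.15 log units; within the scatter).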

Compound 4, half-maximal inhibitory concentration: 34800 nM
Estimate against measurement, compound 4: 1.0-fold (0.00 log units) above; measured number inside the range.
By their numbers in this assay, from the lowest: compounds 4, 2, 1 and 3 (each within the scatter of the next, the first and the last beyond it).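

In this assay the aromatic position receives its first measured change, with a 1.4-fold lower number from compound 2 to compound 4 (0.15 log units; within the scatter) for chloro in place of methoxy. One heavy atom enters for two and the hydrogen-bond acceptor of methoxy is lost, yet compound 4 is not distinguished from compound 2, so methoxy is not shown to be needed at this place, para to a large group. No measured evidence bears on the reason for this result.

Open, going by these compounds, is whether an amine, a carboxylic acid or a longer chain at this place would move the number beyond the scatter. Also open, on these data alone, is whether any other place on the shared core would do so.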